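Moving the Bromine Around the Benzyl Ring

The source may report more compounds than this note shows. Statements on the series, on what has been measured and on what is new or still open speak of the compounds shown alone.

Compound 1 `COc1cc(OC)c(-c2coc3cc(OCc4ccc(Br)cc4)ccc3c2=O)cc1OC` gives the lowest of the two numbers in a functional assay on HepG2 cells (Homo sapiens) for antiproliferative activity, read by MTT assay, with a stated time of 24 h (on this read-out lower numbers stand for stronger inhibition and higher numbers for weaker inhibition), namely 1050 nM. Compound 2 `COc1cc(OC)c(-c2coc3cc(OCc4ccc(C#N)cc4)ccc3c2=O)cc1OC` gives 4230 nM in this assay, a step of a 4.0-fold higher number from compound 1 to compound 2 (0.61 log units; beyond the scatter). Compound 3 `COc1cc(OC)c(-c2coc3cc(OCc4ccccc4Br)ccc3c2=O)cc1OC` differs from compound 1 by 2-bromophenyl in place of 4-bromophenyl on a saturated chain carbon bound to an oxygen on an aromatic ring. For the measured compounds named here, no measured step moves the bromine within its ring; the one measured step exchanges it for another group and is only modest, so nothing here points to a large change in either direction. The estimate for compound 3 is therefore 1300 nM, with a range from 500 nM to 3500 nM, a step of a 1.2-fold higher number from compound 1 to compound 3 (0.09 log units; within the scatter) that is expected to stay within the scatter.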

Compound 3, half-maximal inhibitory concentration: 2180 nM
For compound 3 the middle estimate is 1.7-fold (0.22 log units) below the measured one; the range from low to high includes it.
By their numbers in this assay, from the lowest: compound 1; then compounds 3 and 2 (each within the scatter of the next).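

Moving the bromine is enough on its own to shift the result in this assay: with the same atoms joined differently, the change from 4-bromophenyl to 2-bromophenyl gives a 2.1-fold higher number from compound 1 to compound 3 (0.32 log units; beyond the scatter), so where the bromine sits on this ring matters, and not only whether it is present. The 2-bromophenyl and 4-cyanophenyl compounds are not separated, with a 1.9-fold lower number from compound 2 to compound 3 (0.29 log units; within the scatter). Nothing available gives a reason for these differences. Still open, from the compounds shown here alone, is whether moving a group other than bromine, such as a methoxy group or an amine, would change the number in the same way.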